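The source may report more compounds than this note shows. Statements on the series, on what has been measured and on what is new or still open speak of the compounds shown alone.

Of the compounds shown here, three on one shared core have so far been tested in an ADME assay on L929 cells (Mus musculus) for cytotoxicity, read by resazurin assay, with a stated time of 48 h; a lower number here means that less compound is tolerated, a higher number that more compound is tolerated. Compound 1 `C=Cn1c2ccc([N+](=O)[O-])cc2c(=O)n1Cc1ccccc1` gives 160000 nM. Compound 2 `C=CCn1c2ccc([N+](=O)[O-])cc2c(=O)n1Cc1ccccc1` gives 192000 nM, and the two lie close together, with a 1.2-fold higher number from compound 1 to compound 2 (0.08 log units; within the scatter). Compound 3 `COC(=O)CCn1c2ccc([N+](=O)[O-])cc2c(=O)n1Cc1ccccc1` carries only a limit of the assay, > 256000 nM, and no exact number.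

Compound 4 `O=C(O)CCCn1c2ccc([N+](=O)[O-])cc2c(=O)n1Cc1ccccc1` has not yet been measured in this assay. Its difference from compound 3 is carboxymethyl in place of methoxycarbonyl on a saturated chain carbon, two bonds along the chain from an aromatic nitrogen. The same change reads as 2-(methoxycarbonyl)ethyl to 3-carboxypropyl.

Among the compounds with values here, no measured step makes this exchange, so the evidence is indirect. The closest steps are those that reach compound 3 by changing the chain on the aromatic nitrogen, namely an at least 1.6-fold higher number from compound 1 to compound 3 (0.20 log units; that floor lies within the scatter) and an at least 1.3-fold higher number from compound 2 to compound 3 (0.12 log units; that floor lies within the scatter). On these data alone, their floors lie within the scatter, although each true size remains open. On that basis no shift beyond the scatter is expected in this assay, and no firm direction can be given. The expected change is a step that the limit leaves unreadable from compound 3 to compound 4. The estimate for compound 4 is 280000 nM, with an expected range from 160000 nM to 500000 nM.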

Compound 4, concentration lethal to 50% of the cells: > 256000 nM
Compound 4: no number, only a limit; the forecaster's own chance of this, stated with the estimate: 60%; the middle value does not contradict the limit.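

In this assay, compound 4 carries a limit and not a number, > 256000 nM, so the 3-carboxypropyl chain on the aromatic nitrogen gives a reading that stops at the limit, as the 2-(methoxycarbonyl)ethyl chain of compound 3 does. Exchanging methoxycarbonyl for carboxymethyl at this place, on a saturated chain carbon, two bonds along the chain from an aromatic nitrogen, therefore brings no exact value into view, and the step between these two compounds cannot be read because both rest on the same limit: the limit of > 256000 nM in this assay, at which 2 of the 4 values shown sit. Against the compounds with a number, the result reads as an at least 1.3-fold higher number from compound 2 to compound 4 (0.12 log units; that floor lies within the scatter) and as an at least 1.6-fold higher number from compound 1 to compound 4 (0.20 log units; that floor lies within the scatter), so compound 4 adds a second end group to the chain while both floors stay within the scatter.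

On these data alone, the true size of these steps stays open, as does any difference between the ester and the carboxylic acid in this assay. Also open, as far as these compounds go, is whether an amine, a primary amide or a longer chain at this place would give an exact number rather than a limit.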